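Swapping Chloro for 2-Chlorophenyl at the Assay Limit

The source may hold more compounds than are shown below. What is called first, only, known or untested is meant among the compounds shown, and "the series" means these compounds.

Compound 3 (`CCOC(=O)c1c(-c2cccc(Cl)c2)[nH]c2cc(OC)c(F)cc2c1=O`) gives > 21500 nM in an ADME assay on BJ cells (Homo sapiens) for cytotoxicity, read by luminescence, with a stated time of 72 h (a lower number here means that less compound is needed, a higher number that more compound is needed for the effect), as a limit and not a number. Compound 1 (`CCOC(=O)c1c(-c2cccc(-c3ccccc3)c2)[nH]c2cc(OC)c(F)cc2c1=O`) gives > 21500 nM as a limit too. Compound 2 (`CCOC(=O)c1c(-c2cccc(F)c2)[nH]c2cc(OC)c(F)cc2c1=O`) also gives > 21500 nM as a limit. The measured steps therefore carry no size: there is a step that the two limits leave unreadable from compound 1 to compound 3 with chloro in place of phenyl, and a step that the two limits leave unreadable from compound 2 to compound 3 with chloro in place of fluoro. Compound 4 (`CCOC(=O)c1c(-c2cccc(-c3ccccc3Cl)c2)[nH]c2cc(OC)c(F)cc2c1=O`) carries 2-chlorophenyl in place of chloro on an aromatic carbon. Compound 1, which also has an extra aromatic ring, stays at > 21500 nM as a limit, so no clear step is expected. The estimated change is a number no higher from compound 3 to compound 4 (the limit leaves the size open) in this assay and another limit is the likely outcome. The estimate for compound 4 is 21500 nM with an expected range from 10000 nM to 30000 nM as the likely span.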

Compound 4, half-maximal effective concentration: > 21500 nM
Compound 4 gave a limit, no number; the forecaster's own chance of this, stated with the estimate: 85%; the middle value lies on the limit itself.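

Going by these compounds alone, compound 4 gives only a limit, as do compound 1, compound 2 and compound 3, so no step among them can be read: the limit of > 21500 nM in this assay, at which 4 of the 4 values shown sit. Open, going by these compounds, is whether any of these changes alters the concentration needed in this assay at all.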